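The source may report more compounds than this note shows. Statements on the series, on what has been measured and on what is new or still open speak of the compounds shown alone.

Measured so far in an ADME assay on Vero cells (Chlorocebus sabaeus) for cytotoxicity, read by resazurin assay, with a stated time of 3 days; on this read-out lower numbers stand for stronger inhibition and higher numbers for weaker inhibition:
- compound 1, `CCN(CC)c1cc2[nH]c(C3CCCCC3)nc2cc1NC(=O)OCC(F)(F)F`: compound 1 reaches only the assay limit > 100 ug/mL.
- compound 2, `CCN(CC)c1cc2[nH]c(C3CCCCC3)nc2cc1NC(=O)NCc1ccccc1`: compound 2 reaches only the assay limit > 100 ug/mL.
- compound 3, `O=C(Nc1cc2nc(C3CCCCC3)[nH]c2cc1N1CCCC1)OCC(F)(F)F`: compound 3 reaches only the assay limit > 100 ug/mL.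

Compound 1 and compound 2 differ by benzylamino in place of 2,2,2-trifluoroethoxy on a carbonyl carbon, and in this assay the step is a step that the two limits leave unreadable from compound 1 to compound 2. The two cores differ by pyrrolidin-1-yl in place of diethylamino on an aromatic carbon, giving in this assay the step that the two limits leave unreadable from compound 1 to compound 3. All three values sit at the limit of > 100 ug/mL in this assay, at which 3 of the 3 values shown sit, so no size can be read from any pair.

Compound 4, `O=C(NCc1ccccc1)Nc1cc2nc(C3CCCCC3)[nH]c2cc1N1CCCC1`, awaits measurement in this assay. It differs from compound 3 by benzylamino in place of 2,2,2-trifluoroethoxy on a carbonyl carbon, the same change as the one already measured, whose step was a step that the two limits leave unreadable from compound 1 to compound 2. For compound 4 in this assay the expected step is a step that the limit leaves unreadable from compound 3 to compound 4, resting on that unreadable step and on (the limit of > 100 ug/mL in this assay, at which 3 of the 3 values shown sit). Compound 4 is estimated at 150 ug/mL, between 80 ug/mL and 400 ug/mL, most probably reported again only as a limit.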

Compound 4, half-maximal inhibitory concentration: > 100 ug/mL
Compound 4 gave a limit, no number (the forecaster's own chance of this, stated with the estimate: 85%); the middle value does not contradict the limit.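

No size can be read for the steps from compound 3 or compound 2 to compound 4 in this assay, where each value is only a limit: the limit of > 100 ug/mL in this assay, at which 4 of the 4 values shown sit. The compounds shown leave open at what concentration any of them harms these cells, and whether either change shifts that concentration.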